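This account rests on a few compounds, and the source may have more. Where it says the series, first, only, none or still open, it means among the compounds named here.

Series notes:
- compound 1 `COc1cc(-c2cc(=O)c3ccc(O)cc3o2)cc(OC)c1OC`: 51400 nM
- compound 2 `COc1ccc(-c2cc(=O)c3ccc(OCCCN4CCC(C)CC4)cc3o2)cc1`: 42600 nM

In a functional assay for inhibition, read by fluorescence and spectrophotometry, with a stated time of 30 h (on this read-out lower numbers stand for stronger inhibition and higher numbers for weaker inhibition), compound 2 gives 42600 nM, within the scatter of compound 1 at 51400 nM, so neither ranks ahead of the other. Compound 3 `COc1ccc(-c2cc(=O)c3ccc(OCCCCN4CCC(CCO)CC4)cc3o2)cc1` departs from compound 2 as follows: (4-(2-hydroxyethyl)piperidin-1-yl)methyl in place of 4-methylpiperidin-1-yl on a saturated chain carbon, three bonds along the chain from an oxygen on an aromatic ring. The change sits on a saturated chain carbon, three bonds along the chain from an oxygen on an aromatic ring. Among the measured compounds shown here, no measured pair differs in one place, so the data offer no precedent for its size. In this assay a modest move towards stronger inhibition is expected, with wide uncertainty: a 1.7-fold lower number from compound 2 to compound 3 (0.23 log units; within the scatter). The estimate for compound 3 is 25000 nM, with an expected range of 7000 nM to 80000 nM.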

Compound 3, half-maximal inhibitory concentration: 38400 nM
For compound 3 the middle estimate is 1.5-fold (0.19 log units) below the measured one; the range from low to high includes it.
By their numbers in this assay, from the lowest: compounds 3, 2 and 1 (each within the scatter of the next).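

In this assay, among the compounds shown here, the replacement of 4-methylpiperidin-1-yl by (4-(2-hydroxyethyl)piperidin-1-yl)methyl gives a 1.1-fold lower number from compound 2 to compound 3 (0.05 log units; within the scatter) as the first single-place step at this saturated chain carbon. This position therefore takes the larger group, with its hydrogen-bond donor, without a shift beyond the scatter. No measurement at hand bears on why the read-out holds.

Open, going by these compounds, is how a carboxylic acid or an amine in place of the hydroxy of the 2-hydroxyethyl group would read. Also open, on these data alone, is how a longer chain alone would read with 4-methylpiperidin-1-yl kept.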